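Compound 3 gains a phenyl on its amide-type nitrogen

The source may report more compounds than this note shows. Statements on the series, on what has been measured and on what is new or still open speak of the compounds shown alone.

Compound 3 `O=C1COc2ccc(-c3cnc4ccccc4c3)cc2N1` carries only a hydrogen on its ring nitrogen. In a functional assay on HeLa cells (Homo sapiens) for antiproliferative activity, read by MTT assay, with a stated time of 72 h (on this read-out lower numbers stand for stronger inhibition and higher numbers for weaker inhibition), compound 3 reaches only a limit, > 40000 nM, so it has no exact value. The change to compound 4 `O=C1COc2ccc(-c3cnc4ccccc4c3)cc2N1c1ccccc1` is phenyl in place of hydrogen on an amide-type nitrogen in a ring.

Two close relatives already carry a ring at that nitrogen. Compound 1 `Cc1ccc(N2C(=O)COc3ccc(-c4cnc5ccccc5c4)cc32)cc1`, with 4-methylphenyl, also gives only a limit, > 40000 nM. Compound 2 `COc1ccc(N2C(=O)COc3ccc(-c4cnc5ccccc5c4)cc32)cc1`, with 4-methoxyphenyl, likewise gives only a limit, > 40000 nM. For the measured compounds named here, the steps that bear on the change are a step that the two limits leave unreadable from compound 1 to compound 3 and a step that the two limits leave unreadable from compound 2 to compound 3, so neither offers a size to carry over.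

Going by the values given here, compound 1, compound 2 and compound 3 all share (the limit of > 40000 nM in this assay, at which 3 of the 3 values shown sit), so no measured step points in either direction. No step beyond the scatter is therefore expected in this assay, and compound 4 will probably stop at the same limit. The expected change is a number no higher from compound 3 to compound 4 (the limit leaves the size open). Compound 4 is estimated at 40000 nM, with an expected range from 15000 nM to 80000 nM.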

Compound 4, half-maximal inhibitory concentration: > 40000 nM
Compound 4: only a limit was reported (the forecaster's own chance of this, stated with the estimate: 85%); the middle value lies on the limit itself.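

No step among compound 1, compound 2, compound 3 and compound 4 can be read, since each gives only a limit and not a number: the limit of > 40000 nM in this assay, at which 4 of the 4 values shown sit.

These compounds leave open whether any ring on the amide-type nitrogen changes antiproliferative activity at all.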